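The source may hold more compounds than are shown below. What is called first, only, known or untested is meant among the compounds shown, and "the series" means these compounds.

In an ADME assay on HeLa cells (Homo sapiens) for cytotoxicity, read by crystal violet staining, with a stated time of 72 h (a higher number here means that more compound is tolerated, a lower number that less compound is tolerated), compound 1 `COC(=O)c1cc(CCCOc2c(C)cc(-c3noc(C(F)(F)F)n3)cc2C)on1` gives 35400 nM as its reading. Compound 3 `CCOC(=O)c1cc(CCCOc2ccc(-c3noc(C(F)(F)F)n3)cc2C(F)(F)F)on1` gives 28400 nM there, within the scatter of compound 1, so these two readings cannot be ranked. Compound 2 `CCOC(=O)c1cc(CCCOc2ccc(-c3noc(C(F)(F)F)n3)cc2OC)on1` gives > 100000 nM as its reading, which is a limit of the assay and not a number.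

Compound 4 `COc1ccc(-c2cc(CCCOc3c(C)cc(-c4noc(C(F)(F)F)n4)cc3C)on2)cc1OC` differs from compound 1 by 3,4-dimethoxyphenyl in place of methoxycarbonyl on an aromatic carbon and carries 3,4-dimethoxyphenyl in place of methoxycarbonyl on an aromatic carbon of a five-membered aromatic ring with 1 nitrogen and 1 oxygen. Among the compounds with values here, the set holds only one measured step, an at least 3.5-fold lower number from compound 2 to compound 3 (0.54 log units; beyond the scatter) and it comes with trifluoromethyl in place of methoxy on an aromatic carbon. Within the data shown here, that step shows that a single swap can move the reading beyond the scatter, but it is a different swap from the one in compound 4, so it points in no direction here.

The expected result in this assay is a 1.0-fold lower number from compound 1 to compound 4 (0.00 log units; within the scatter) and no shift beyond the scatter is expected, although this expectation is uncertain. Compound 4 might also reach the limit of > 100000 nM in this assay, at which 1 of the 3 values shown sits, and give no number. For compound 4 the estimate is 35000 nM (expected range 10000 nM to 100000 nM).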

Compound 4, half-maximal cytotoxic concentration: 41900 nM
Beside the measured number, compound 4's estimate is 1.2-fold (0.08 log units) below it; the range from low to high includes it.
By their numbers in this assay, from the lowest: compounds 3, 1 and 4 (each within the scatter of the next). At a limit, above all of these: compound 2.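

Putting 3,4-dimethoxyphenyl in place of methoxycarbonyl, on the aromatic carbon next to the ring nitrogen of the five-membered aromatic ring, gives in this assay a 1.2-fold higher number from compound 1 to compound 4 (0.07 log units; within the scatter). Within the data shown here, this is the only view of this position so far, and the entering group is much larger than the one it replaces, bringing a six-membered aromatic ring of carbon only where methoxycarbonyl has no ring. Among these compounds, the one earlier step, an at least 3.5-fold lower number from compound 2 to compound 3 (0.54 log units; beyond the scatter), comes with a different swap and shows that a reading in this set can move beyond the scatter, whereas this larger group at this position leaves the reading of the core of compound 1 within it.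

With only these two groups shown at this position, it stays open whether an amine, a carboxylic acid or a longer chain placed there would also leave the reading in place. Compound 2 adds no number to compare with the others, since its reading is only a limit: the limit of > 100000 nM in this assay, at which 1 of the 4 values shown sits.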